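Extending the ketone chain of compound 2 by one carbon

The compounds below may be only part of what the source reports. "The series", "measured", "known", "first", "only" and "open" are said of these compounds alone.

Compound 2 `CCC(=O)c1ccc(OCCCCOc2cccc(C(=O)O)c2C)c(C)c1O` gives 62 nM in an assay on HEK293 cells for positive allosteric modulation of metabotropic glutamate receptor 2 (Rattus norvegicus), read by thallium flux, with a stated time of 2.5 min (on this read-out higher numbers stand for an effect only at larger amounts of compound and lower numbers for an effect already at smaller amounts), the lowest of the three numbers recorded. Its nearest neighbour is compound 1 `Cc1c(OCCCCOc2ccc(C(=O)CC(C)(C)C)c(O)c2C)cccc1C(=O)O` with 136 nM; compound 3 `COc1ccc(C(=O)O)cc1OCCCCOc1ccc(C(C)=O)c(O)c1C` stands furthest away at 1090 nM. Compound 4 `CCCC(=O)c1ccc(OCCCCOc2cccc(C(=O)O)c2C)c(C)c1O` has not yet been measured. It differs from compound 2 by methyl in place of hydrogen on a saturated chain carbon, two bonds along the chain from a carbonyl carbon.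

Among the measured compounds shown here, only one measured step bears on this change. Going from compound 1 to compound 2, the saturated carbon bound to the carbonyl carried methyl in place of tert-butyl, and the number moved a 2.2-fold lower number from compound 1 to compound 2 (0.34 log units; beyond the scatter). That step shortened the ketone chain and improved the number modestly; the change to compound 4 lengthens it by one carbon, so a small move in the opposite direction, at most at the edge of the scatter, seems the likeliest outcome. Compound 4 is therefore expected to show a 1.5-fold higher number from compound 2 to compound 4 (0.16 log units; within the scatter). The estimate for compound 4 is 90 nM, with a range from 40 nM to 200 nM.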

Compound 4, half-maximal effective concentration: 52 nM
Beside the measured number, compound 4's estimate is 1.7-fold (0.24 log units) above it; measured number inside the range.
By their numbers in this assay, from the lowest: compounds 4 and 2 (each within the scatter of the next); then compound 1; then compound 3.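

In this assay, the added methyl gives a 1.2-fold lower number from compound 2 to compound 4 (0.08 log units; within the scatter), so the ethyl and propyl ends of the ketone chain cannot be told apart at this place. Ethyl in place of tert-butyl on the saturated chain carbon bound to a carbonyl carbon gives a 2.6-fold lower number from compound 1 to compound 4 (0.42 log units; beyond the scatter), so compound 4 and compound 2 both stand apart from compound 1, the one compound of the three carrying tert-butyl there. No measurement accompanies these numbers that could account for them.

The compounds shown leave open whether a longer chain such as butyl, or a branched isopropyl at the same place, would stay with compound 2 and compound 4 or move toward compound 1. They also leave open what a hydroxyl or an amine on this chain would do.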